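The source may report more compounds than this note shows. Statements on the series, on what has been measured and on what is new or still open speak of the compounds shown alone.

Compound 1, `CCCCc1cn([C@H]2C[C@H](O)[C@@H](CO)O2)c(=O)[nH]c1=O`, carries a butyl chain on its core and was tested in a functional assay on L1210 cells (Mus musculus); on this read-out higher numbers stand for weaker inhibition and lower numbers for stronger inhibition. In this assay compound 1 gives only a limit, > 500 ug/mL, and not a number. Compound 3, `CCCc1cn([C@H]2C[C@H](O)[C@@H](CO)O2)c(=O)[nH]c1=O`, differs from compound 1 by hydrogen in place of methyl on a saturated chain carbon, three bonds along the chain from an aromatic carbon. In this assay compound 3 likewise gives only a limit, > 500 ug/mL. The step that the two limits leave unreadable from compound 1 to compound 3 therefore cannot be read, because both values sit at the limit of > 500 ug/mL in this assay, at which 3 of the 3 values shown sit.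

Compound 2, `CCCCCc1cn([C@H]2C[C@@H]3OP(=O)(O)OC[C@H]3O2)c(=O)[nH]c1=O`, is built on a second core; the difference between the two cores is not broken down here. In this assay compound 2 also gives only a limit, > 500 ug/mL.

Compound 4, `CCCCc1cn([C@H]2C[C@@H]3OP(=O)(O)OC[C@H]3O2)c(=O)[nH]c1=O`, has not yet been measured in this assay. It differs from compound 2 by hydrogen in place of methyl on a saturated chain carbon, four bonds along the chain from an aromatic carbon. This is the same kind of change as that from compound 1 to compound 3, but not the same: in the earlier pair the change sits three bonds along the chain from an aromatic carbon, whereas here it sits four bonds along the chain from an aromatic carbon.

Since all three measured values, including that of compound 2, sit at a limit, the expectation rests on compound 2 alone: the step from compound 2 to compound 4 is expected to be about a step that the limit leaves unreadable from compound 2 to compound 4. Compound 4 is accordingly expected to give around 600 ug/mL, within 250 ug/mL and 2000 ug/mL, and most likely only a limit again.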

Compound 4, concentration for 50% inhibition: 33.5 ug/mL
Estimate against measurement, compound 4: 18-fold (1.25 log units) above; the measured number lies below the stated range.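

In this assay compound 2 gives only a limit, > 500 ug/mL, and not a number, so the size of the new step is a minimum and not an exact figure. On the core of compound 2, hydrogen in place of methyl, four bonds along the chain from an aromatic carbon, gives an at least 14-fold lower number from compound 2 to compound 4 (1.17 log units; beyond the scatter), which is a large step and means stronger inhibition for compound 4. This does not show that the change carries from one core to the other, since the step on the core of compound 1, where the change sits three bonds along the chain from an aromatic carbon, cannot be read and both of its compounds sit at a limit: the limit of > 500 ug/mL in this assay, at which 3 of the 4 values shown sit.

The effect is therefore seen on one core and at one place on the chain, and the two pairs cannot separate a difference of core from a difference of place. From the compounds shown here alone, whether a propyl chain on the core of compound 2 would extend the step or reverse it stays open, as does what a chain carrying an amine or a carboxylic acid would give on either core.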